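This account rests on a few compounds, and the source may have more. Where it says the series, first, only, none or still open, it means among the compounds named here.

Measured so far:
- compound 1, `O=C(NC[C@H](NS(=O)(=O)c1ccccc1)C(=O)O)c1ccc(N2CCC(NC3=NCCCN3)CC2)c(O)c1`: 170 nM
- compound 2, `O=C(NC[C@H](NS(=O)(=O)c1ccc(O)cc1)C(=O)O)c1ccc(N2CCC(NC3=NCCCN3)CC2)c(F)c1`: 230 nM

In a functional assay on a cell-free system (Platelet, plasma, Homo sapiens) for inhibition (a higher number here means a weaker inhibitor, a lower number a stronger inhibitor), compound 1 gives 170 nM, the lowest of the two numbers recorded. Compound 2 gives 230 nM in this assay, and the gap between these two values lies within the usual scatter, so the two compounds cannot be told apart on these data. Compound 3, `COc1cc(C(=O)NC[C@H](NS(=O)(=O)c2ccccc2)C(=O)O)ccc1N1CCC(NC2=NCCCN2)CC1`, has not yet been measured. It differs from compound 1 in one place, (methyl in place of hydrogen on an oxygen on an aromatic ring). Among the compounds with values here, no single-change step between measured compounds is available, so the size of this step in this assay is unknown. Given that compound 1 and compound 2 sit so close together despite differences at two places, compound 3 is expected to stay near its parent, with a step of a 1.5-fold higher number from compound 1 to compound 3 (0.17 log units; within the scatter) that may not exceed the scatter. Compound 3 is estimated at 250 nM, within 100 nM to 650 nM.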

Compound 3, half-maximal inhibitory concentration: 130 nM
The estimate for compound 3 lay 1.9-fold (0.28 log units) above the measured number; low and high end bracket the measured number.
By their numbers in this assay, from the lowest: compounds 3, 1 and 2 (each within the scatter of the next).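

In this assay, within the data shown here, the change from hydroxy to methoxy gives the first step that can be read at a single place: a 1.3-fold lower number from compound 1 to compound 3 (0.12 log units; within the scatter). Methyl in place of hydrogen on this oxygen on an aromatic ring therefore leaves the inhibition indistinguishable from that of compound 1, so these data show no need for the free hydroxy hydrogen in this assay. Nothing available gives a reason for this outcome.

On these data alone, it remains open whether a longer chain on this oxygen, such as ethyl or benzyl, or an amine in place of the hydroxy would also leave the value unchanged. Compound 2 differs from compound 1 in two places, so the separate contributions of its fluoro and its second hydroxy group cannot be read.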